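From Compound 2 to Compound 4: Hydroxy Becomes Methylcarbamoyl

The compounds below may be only part of what the source reports. "The series", "measured", "known", "first", "only" and "open" are said of these compounds alone.

Compound 2 `CC1CC/C(=N\Nc2ccc(O)cc2)c2ncc(C(=O)O)c(=O)n21` carries a 4-hydroxyphenyl group on the amine nitrogen of the shared core. In a functional assay on the whole organism for inhibition, with Rattus norvegicus as the target (a higher number here means that more compound is needed for the effect, a lower number that less compound is needed), compound 2 gives only a limit, > 100 umol/kg, so its true dose is not known as a number. Among the other measured compounds, compound 1 `CC1CC/C(=N\Nc2cccc(I)c2)c2ncc(C(=O)O)c(=O)n21`, with a 3-iodophenyl group in the same position, gives 1000 umol/kg. Compound 3 `COc1ccccc1N/N=C1\CCC(C)n2c1ncc(C(=O)O)c2=O`, with a 2-methoxyphenyl group there, also ends at a limit in this assay, namely > 1000 umol/kg. The three steps between these compounds, a step that the limit leaves unreadable from compound 1 to compound 2, a number no lower from compound 1 to compound 3 (the limit leaves the size open) and a step that the two limits leave unreadable from compound 2 to compound 3, cannot be given a size because the limit of > 100 umol/kg in this assay, at which 1 of the 3 values shown sits, and the limit of > 1000 umol/kg in this assay, at which 1 of the 3 values shown sits, hide where the affected compounds truly sit.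

Compound 4 `CNC(=O)c1ccc(N/N=C2\CCC(C)n3c2ncc(C(=O)O)c3=O)cc1` differs from compound 2 in one place: methylcarbamoyl in place of hydroxy on an aromatic carbon. For the measured compounds named here, no measured step exchanges a hydroxy for a methylcarbamoyl, and the steps that touch this part of the molecule are all unreadable, so no direction can be read from the measured compounds. The expected step that the limit leaves unreadable from compound 2 to compound 4 is therefore estimated to stay within the scatter. Compound 4 is therefore estimated at 1000 umol/kg, with a range from 300 umol/kg to 3000 umol/kg, and a fair chance that this assay again reports only a limit.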

Compound 4, dose for 50% inhibition: > 100 umol/kg
Compound 4: no number, only a limit; the forecaster's own chance of this, stated with the estimate: 50%; the middle value does not contradict the limit.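

In this assay compound 4 gives only a limit, > 100 umol/kg. Compound 2 also ends at a limit, so the step between compound 2 and compound 4 cannot be read: the limit of > 100 umol/kg in this assay, at which 2 of the 4 values shown sit. The compounds shown leave open where compound 2 and compound 4 truly sit, and whether methylcarbamoyl or hydroxy on the aromatic carbon needs the smaller dose.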